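From 4-bromophenyl to 2-bromophenyl on the sulfonyl sulfur

This account rests on a few compounds, and the source may have more. Where it says the series, first, only, none or still open, it means among the compounds named here.

Three compounds with a shared core, differing only in the aryl group on the sulfonyl sulfur, have been measured in a functional assay on HeLa cells (Homo sapiens) for cytotoxicity, read by sulforhodamine B assay; a lower number here means a stronger inhibitor, a higher number a weaker inhibitor. In that test compound 1 `Cc1ccccc1S(=O)(=O)NC(C1=CC(=O)c2c(O)ccc(O)c2C1=O)C(C)C`, with 2-methylphenyl, gives 790 nM. Compound 2 `COc1ccc(S(=O)(=O)NC(C2=CC(=O)c3c(O)ccc(O)c3C2=O)C(C)C)c(OC)c1`, with 2,4-dimethoxyphenyl, gives 2750 nM. Compound 3 `CC(C)C(NS(=O)(=O)c1ccc(Br)cc1)C1=CC(=O)c2c(O)ccc(O)c2C1=O`, with 4-bromophenyl, gives 7650 nM, the highest number of the three and so the weakest inhibition in this small set.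

Compound 4 `CC(C)C(NS(=O)(=O)c1ccccc1Br)C1=CC(=O)c2c(O)ccc(O)c2C1=O` has the same atoms as compound 3, joined differently, with 2-bromophenyl in place of 4-bromophenyl on a sulfonyl sulfur. Within the data shown here, no measured pair isolates this exact change. The nearest evidence is the aryl exchanges: a 9.7-fold higher number from compound 1 to compound 3 (0.99 log units; beyond the scatter), a 2.8-fold higher number from compound 2 to compound 3 (0.44 log units; beyond the scatter) and a 3.5-fold higher number from compound 1 to compound 2 (0.54 log units; beyond the scatter). All three are modest steps, though beyond the scatter, so this aryl group does matter in this assay. The expectation leans on compound 1, whose 2-methylphenyl name shares its numbering with the incoming group, and which gives 790 nM. With so few compounds, this is a weak guide. A modest step towards a lower number is therefore expected, namely a 3.5-fold lower number from compound 3 to compound 4 (0.54 log units; beyond the scatter). For compound 4 the estimated value is 2200 nM, with an expected range from 700 nM to 7000 nM.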

Compound 4, half-maximal inhibitory concentration: 8310 nM
Compound 4: middle estimate off by 3.8-fold (0.58 log units), on the low side, and the stated range ends below it.
By their numbers in this assay, from the lowest: compound 1; then compound 2; then compounds 3 and 4 (each within the scatter of the next).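

In this assay, 2-bromophenyl in place of 4-bromophenyl on the sulfonyl sulfur gives a 1.1-fold higher number from compound 3 to compound 4 (0.04 log units; within the scatter) and so leaves the reading unchanged, which means the two bromophenyl isomers cannot be told apart in this test. The new compound also separates the name from the group, since bromo in place of methyl on an aromatic carbon gives an 11-fold higher number from compound 1 to compound 4 (1.02 log units; beyond the scatter) and the low number of compound 1 therefore does not carry over to a compound whose group shares its numbering. Compound 4 also stands on the weaker side of the dimethoxy compound, with 2-bromophenyl in place of 2,4-dimethoxyphenyl giving a 3.0-fold higher number from compound 2 to compound 4 (0.48 log units; beyond the scatter), so both bromophenyl compounds read higher than compound 2 and compound 1.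

Nothing available explains why the two bromophenyl compounds match or why the methyl compound differs from them. Still open, on these data alone, is whether the stronger inhibition of compound 1 is particular to methyl or would also appear with a chlorine, an ethyl group, a single methoxy group, an amine or a carboxylic acid on the same phenyl ring.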